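Demethylation of an aryl methyl ether on two urea cores

The source may report more compounds than this note shows. Statements on the series, on what has been measured and on what is new or still open speak of the compounds shown alone.

Measured so far in a functional assay on HOP-92 cells (Homo sapiens) for inhibition, read by sulforhodamine B assay, with a stated time of 48 h; a higher number here means that more compound is tolerated, a lower number that less compound is tolerated:
compound 1 `COc1cc(-c2nn(-c3cccc(NC(=O)Nc4cc(C(F)(F)F)cc(C(F)(F)F)c4)c3)cc2-c2ccncc2)ccc1Cl` — 4720 nM
compound 2 `O=C(Nc1cccc(-n2cc(-c3ccncc3)c(-c3ccc(Cl)c(O)c3)n2)c1)Nc1cc(C(F)(F)F)cc(C(F)(F)F)c1` — 8660 nM
compound 3 `COc1cc(-c2nn(-c3cccc(NC(=O)Nc4ccc(Cl)c(C(F)(F)F)c4)c3)cc2-c2ccncc2)ccc1Cl` — > 32500 nM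

Compound 1 carries a 4-chloro-3-methoxyphenyl group, and compound 2 is its counterpart in which the ether is opened: hydrogen in place of methyl on an oxygen on an aromatic ring. In this assay this change gave a 1.8-fold higher number from compound 1 to compound 2 (0.26 log units; within the scatter), a step that stays within the scatter, so the two values are taken as alike.

Compound 3 rests on a different core, and the difference between the two cores is not broken down here. For compound 3 this assay gives only a limit, > 32500 nM, and no number.

Compound 4 `O=C(Nc1cccc(-n2cc(-c3ccncc3)c(-c3ccc(Cl)c(O)c3)n2)c1)Nc1ccc(Cl)c(C(F)(F)F)c1` is the corresponding demethylated form of compound 3; the change is the same kind as before: hydrogen in place of methyl on an oxygen on an aromatic ring. Among the compounds with values here, since the one measured step of this kind was within the scatter, and since compound 3 already sits at the limit of > 32500 nM in this assay, at which 1 of the 3 values shown sits, the step from compound 3 to compound 4 is expected to be a step that the limit leaves unreadable from compound 3 to compound 4, and the expected value for compound 4 is about 50000 nM, most likely again reported only as a limit.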

Compound 4, concentration lethal to 50% of the cells: 13500 nM
Compound 4: middle estimate off by 3.7-fold (0.57 log units), on the high side; measured number outside the range, below it.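

In this assay, replacing methoxy with hydroxy on the second core gave an at least 2.4-fold lower number from compound 3 to compound 4 (0.38 log units; beyond the scatter). Set beside the earlier step, the same change did not read the same on the two cores: the same change on two cores in this assay, a 1.8-fold higher number (0.26 log units; within the scatter) from compound 1 to compound 2 and an at least 2.4-fold lower number (0.38 log units; beyond the scatter) from compound 3 to compound 4, at least 4.4-fold (0.64 log units) apart, beyond the scatter of two such steps This shows that, for these two pairs, the outcome of the change depended on the core it was placed on, but it does not show what in the core is responsible, and it gives no exact size for the second step, as compound 3 is held only as a limit: the limit of > 32500 nM in this assay, at which 1 of the 4 values shown sits.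

With only two pairs, the compounds shown leave open whether either outcome would recur on any further core in this series. They also leave open how this assay would read with an ethyl group or a longer chain on the same oxygen, or with an amine or a carboxylic acid in place of the hydroxy group of the 4-chloro-3-hydroxyphenyl ring.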